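This account rests on a few compounds, and the source may have more. Where it says the series, first, only, none or still open, it means among the compounds named here.

The measured compounds so far:
compound 1, `Cc1cc(S(=O)(=O)/N=C(\N)n2nccc2-c2ccccc2)c(SCc2ccc(C(F)(F)F)cc2)cc1Cl`, 14000 nM
compound 2, `Cc1cc(S(=O)(=O)/N=C(\N)n2nccc2-c2ccccc2)c(SCc2ccc(Cl)cc2)cc1Cl`, 7000 nM
compound 3, `Cc1cc(-c2ccccc2)n(/C(N)=N/S(=O)(=O)c2cc(C)c(Cl)cc2SCc2ccccc2C(F)(F)F)n1`, 25000 nM

All three were tested in a functional assay on HCT-116 cells (Homo sapiens) for cytotoxicity, read by MTT assay, with a stated time of 72 h; on this read-out higher numbers stand for weaker inhibition and lower numbers for stronger inhibition. Compound 1 and compound 2 share a core and differ by one change, (chloro in place of trifluoromethyl on an aromatic carbon), which gave a 2.0-fold lower number from compound 1 to compound 2 (0.30 log units; within the scatter). Compound 3 carries a different core; the difference between the two cores is not broken down here. In this assay compound 3 sits at the highest of the three numbers, close to compound 1 and further from compound 2.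

Compound 4, `Cc1cc(-c2ccccc2)n(/C(N)=N/S(=O)(=O)c2cc(C)c(Cl)cc2SCc2ccccc2Cl)n1`, has not been measured. It differs from compound 3 by chloro in place of trifluoromethyl on an aromatic carbon. Going by the values given here, this is the same kind of change as the one from compound 1 to compound 2, but not the same: in the earlier pair the changed carbon is "para to a large group", whereas here it is "ortho to a large group". Resting on the earlier step of a 2.0-fold lower number from compound 1 to compound 2 (0.30 log units; within the scatter), a step of similar size is expected from compound 3 to compound 4, namely a 1.7-fold lower number from compound 3 to compound 4 (0.22 log units; within the scatter). Compound 4 is therefore estimated at 15000 nM in this assay, expected to lie between 6000 nM and 40000 nM.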

Compound 4, half-maximal inhibitory concentration: 170000 nM
Estimate against measurement, compound 4: 11-fold (1.05 log units) below; the measured number lies above the stated range.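

In this assay, putting chloro in place of trifluoromethyl on an aromatic carbon gave a 6.8-fold higher number from compound 3 to compound 4 (0.83 log units; beyond the scatter), so the step seen on the core of compound 1 did not carry over to the core of compound 3: the same change on two cores in this assay, a 2.0-fold lower number (0.30 log units; within the scatter) from compound 1 to compound 2 and a 6.8-fold higher number (0.83 log units; beyond the scatter) from compound 3 to compound 4, 14-fold (1.13 log units) apart, beyond the scatter of two such steps

The two pairs differ not only in their cores but also in the place of the change, which is ortho to a large group in compound 3 and compound 4 but not in the earlier pair, and the data cannot separate these two differences. Going by these compounds alone, two pairs show only that this change cannot safely be carried from one core to another; they establish no general rule and give no cause for the gap.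

The compounds shown leave open whether the same change at the same place would give a similar step on the core of compound 1. They also leave open how a methoxy group or a nitrile would compare at that aromatic carbon on either core.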